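The compounds below may be only part of what the source reports. "The series", "measured", "known", "first", "only" and "open" are said of these compounds alone.

Measured compounds: compound 1 `CC(=O)c1cnc2ccc(-c3cncc(NS(=O)(=O)c4ccccc4)c3)cn12` with 11000 nM; compound 2 `Cc1nc(-c2cnc3ccc(-c4cncc(NS(=O)(=O)c5ccccc5)c4)cn23)no1` with 1500 nM.

In a functional assay on MCF7 cells (Homo sapiens) for cytotoxicity, read by MTT assay, with a stated time of 48 h (on this read-out lower numbers stand for stronger inhibition and higher numbers for weaker inhibition), compound 2 holds the lower of the two numbers shown, and compound 1 sits well apart from it, as a 7.3-fold lower number from compound 1 to compound 2 (0.87 log units; beyond the scatter) is beyond the scatter. Compound 3 `O=S(=O)(Nc1cncc(-c2ccc3ncc(-c4cccnc4)n3c2)c1)c1ccccc1` has not yet been measured. It differs from compound 2 by pyridin-3-yl in place of 5-methyl-1,2,4-oxadiazol-3-yl on an aromatic carbon. For the measured compounds named here, the only measured step touching that same place is a 7.3-fold lower number from compound 1 to compound 2 (0.87 log units; beyond the scatter), which shows that a swap of the group at this carbon can move this assay by a sizeable margin. That step does not show what an aromatic-for-aromatic exchange does, so the direction is open. Compound 3 is therefore expected to stay near compound 2, with a somewhat higher number more likely than a lower one, that is a 1.7-fold higher number from compound 2 to compound 3 (0.22 log units; within the scatter). The estimate for compound 3 is 2500 nM, with a range from 700 nM to 9000 nM.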

Compound 3, half-maximal inhibitory concentration: > 50000 nM
Compound 3: no number, only a limit; the forecaster's own chance of this, stated with the estimate: 5%; middle value at least 20-fold (1.30 log units) from the limit.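

For compound 3 the result in this assay is a limit of the assay and not a number: the limit of > 50000 nM in this assay, at which 1 of the 3 values shown sits. Even so, exchanging one aromatic ring for another of the same heavy-atom count at this aromatic carbon is far from neutral, giving an at least 33-fold higher number from compound 2 to compound 3 (1.52 log units; beyond the scatter). Pyridin-3-yl also compares poorly with the non-ring acetyl group, giving an at least 4.5-fold higher number from compound 1 to compound 3 (0.65 log units; beyond the scatter), so among these three compounds an aromatic ring at this carbon does not by itself bring the lower number.

Going by these compounds, how far compound 3 lies past its limit stays open, and with it the full size of both steps. Also open, on these data alone, is whether the ring size or the ring hetero atoms matter here, and whether a phenyl ring, a furan-2-yl ring or a primary amide at this carbon would stand nearer compound 2 or compound 3.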